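The source may report more compounds than this note shows. Statements on the series, on what has been measured and on what is new or still open speak of the compounds shown alone.

Measured in a functional assay on MCF7 cells (Homo sapiens) for antiproliferative activity, read by MTT assay, with a stated time of 48 h; on this read-out higher numbers stand for weaker inhibition and lower numbers for stronger inhibition:
Compound 1 `C#CCCOC(=O)c1ccc(C(CC)(CC)c2ccc(OCCC(O)(CC)CC)c(C)c2)n1CC`: > 50000 nM
Compound 2 `CCC(C)C(CO)NC(=O)c1ccc(C(CC)(CC)c2ccc(OCCC(O)(CC)CC)c(C)c2)n1CC`: 29100 nM

Compound 1 shows > 50000 nM, which is a limit of the assay and not a number. Among the measured compounds shown here, compound 2, at 29100 nM, therefore holds the only actual number in this assay so far. For the measured compounds named here, the one measured step is an at least 1.7-fold lower number from compound 1 to compound 2 (0.23 log units; that floor lies within the scatter). It puts (1-(hydroxymethyl)-2-methylbutyl)amino in place of (but-3-yn-1-yl)oxy on a carbonyl carbon, so it does not test the sec-butyl group and gives little guidance on its removal.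

Compound 3 `CCn1c(C(=O)NC(C)CO)ccc1C(CC)(CC)c1ccc(OCCC(O)(CC)CC)c(C)c1` carries methyl in place of sec-butyl on a saturated chain carbon bound to an amide-type nitrogen and a saturated chain carbon. Going by the values given here, with only that step from compound 2 to draw on, no change beyond the scatter is expected in this assay, and the expected step is a 1.1-fold higher number from compound 2 to compound 3 (0.04 log units; within the scatter). For compound 3 the estimated value is 32000 nM, within an expected range of 14000 nM to 50000 nM.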

Compound 3, half-maximal inhibitory concentration: 12600 nM
Compound 3: the middle estimate sits 2.5-fold (0.40 log units) above what was measured; the measured number lies below the stated range.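

Cutting sec-butyl back to methyl on this saturated chain carbon gives a 2.3-fold lower number from compound 2 to compound 3 (0.36 log units; beyond the scatter), so in this assay this position responds to the change, and the sec-butyl group is not required for the activity seen there. Among the compounds shown here, in place of (but-3-yn-1-yl)oxy on a carbonyl carbon, (1-(hydroxymethyl)ethyl)amino gives an at least 3.9-fold lower number from compound 1 to compound 3 (0.59 log units; beyond the scatter), a step that, unlike the one to compound 2, clears the scatter. That step is only a floor, because compound 1 stands at a limit of the assay and not at a number: the limit of > 50000 nM in this assay, at which 1 of the 3 values shown sits.

The compounds shown compare only sec-butyl and methyl at this carbon, so they give two points and no trend. On these data alone, whether an ethyl group or a hydrogen there would lower the number further stays open, as does what the hydroxymethyl group contributes.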